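This account rests on a few compounds, and the source may have more. Where it says the series, first, only, none or still open, it means among the compounds named here.

In a functional assay on HL-60 cells (Homo sapiens) for inhibition, read by MTT assay, with a stated time of 72 h (a lower number here means a stronger inhibitor, a higher number a weaker inhibitor), compound 1 `Cc1nc(-c2ccccc2)c(C(=O)N2CCN(c3cccc(Cl)c3)CC2)o1` gives 39.2 nM. Compound 2 `Cc1nc(-c2ccccc2)c(C(=O)N2CCN(c3ccc(F)cc3)CC2)o1` gives > 1000 nM, which is a limit of the assay and not a number. Compound 2 therefore stands at the limit of > 1000 nM in this assay, at which 1 of the 2 values shown sits.

Compound 3 `Cc1nc(-c2ccccc2)c(C(=O)N2CCN(c3ccc(Cl)c(Cl)c3)CC2)o1` differs from compound 2 by 3,4-dichlorophenyl in place of 4-fluorophenyl on an amine nitrogen in a ring. Within the data shown here, only one measured step bears on this change: an at least 25-fold higher number from compound 1 to compound 2 (1.40 log units; beyond the scatter). That step is large and beyond the scatter, and it is the same kind of exchange at the same place, with 4-fluorophenyl in place of 3-chlorophenyl.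

The 3,4-dichlorophenyl of compound 3 keeps the chlorine of the 3-chlorophenyl in compound 1 and loses the fluorine of compound 2. A large step towards a lower number is therefore expected in this assay, though this rests on a single pair and one end of it is a limit. The expected step is an at least 14-fold lower number from compound 2 to compound 3 (1.15 log units; beyond the scatter). Compound 3 is estimated at 70 nM, with an expected range of 15 nM to 400 nM.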

Compound 3, half-maximal inhibitory concentration: 124 nM
The estimate for compound 3 lay 1.8-fold (0.25 log units) below the measured number, within the range that was stated.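

In this assay, among these compounds, replacing 4-fluorophenyl with 3,4-dichlorophenyl on the amine nitrogen in the ring gives an at least 8.0-fold lower number from compound 2 to compound 3 (0.90 log units; beyond the scatter), so this position can return to a measurable value from the limit seen with compound 2, and the large step from the earlier pair is no longer the only evidence here. The added chloro is not a gain over the single-chloro group, however: chloro in place of hydrogen on an aromatic carbon gives a 3.2-fold higher number from compound 1 to compound 3 (0.50 log units; beyond the scatter), so the 3-chlorophenyl of compound 1 remains the better of the two chlorine-bearing groups shown. The value of compound 2 is a limit of the assay and not a number, which leaves the true size of the first step open at one end: the limit of > 1000 nM in this assay, at which 1 of the 3 values shown sits.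

The compounds shown do not separate the loss of chloro from the entry of fluoro in compound 2, a question that 4-chlorophenyl or plain phenyl on the same nitrogen would address. Also open, going by these compounds, is how a methoxy, nitrile or trifluoromethyl group in place of chloro on this aromatic ring would read in this assay.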